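Bromo in Place of Chloro on the Sulfanyl Analogue

A few compounds are considered here, and "the series" means these few. Any claim that something is new, unique, unknown or untested is made for them only; others in the source may bear on it.

Three compounds share one core: compound 1 `CC(=O)OCc1ccc2oc(=O)c(C(=O)Oc3cccc(Cl)c3)cc2c1`, compound 2 `CC(=O)OCc1ccc2oc(=O)c(C(=O)Oc3cccc(Br)c3)cc2c1` and compound 3 `CC(=O)OCc1ccc2oc(=O)c(C(=O)Sc3cccc(Cl)c3)cc2c1`. In a functional assay on HT-1080 cells (Homo sapiens), read by transwell migration, with a stated time of 24 h, tested at 1 uM (on this read-out higher numbers stand for a weaker effect at the one concentration tested and lower numbers for a stronger effect), compound 3 gives 65.8%, the highest of the three numbers; compound 1 gives 49.1% and compound 2 gives 21.8%, and the steps of a number 16.7 percentage points higher from compound 1 to compound 3 (beyond the scatter) and a number 44 percentage points higher from compound 2 to compound 3 (beyond the scatter) both lie beyond the scatter. Compound 4 `CC(=O)OCc1ccc2oc(=O)c(C(=O)Sc3cccc(Br)c3)cc2c1` differs from compound 3 by bromo in place of chloro on an aromatic carbon. Within the data shown here, the one measured step that bears on this change is a number 27.3 percentage points lower from compound 1 to compound 2 (beyond the scatter), made on the 3-chlorophenoxy analogue. A step of the same direction and of modest size is therefore expected here, which would be a number 20.8 percentage points lower from compound 3 to compound 4 (beyond the scatter). Compound 4 is estimated at 45%, with a range from 25% to 65%.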

Compound 4, a percentage reported as activity, at one concentration (the size of the read-out at that concentration, not a potency): 70.9%
Beside the measured number, compound 4's estimate is 25.9 percentage points below it, and the stated range ends below it.
By their numbers in this assay, from the lowest: compound 2; then compound 1; then compounds 3 and 4 (each within the scatter of the next).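

On the sulfanyl analogues the bromo-for-chloro change gives a number 5.1 percentage points higher from compound 3 to compound 4 (within the scatter), so the effect seen on the phenoxy pair in this assay does not carry over to this core: the same change on two cores in this assay, a number 27.3 percentage points lower (beyond the scatter) from compound 1 to compound 2 and a number 5.1 percentage points higher (within the scatter) from compound 3 to compound 4, 32.4 percentage points apart, beyond the scatter of two such steps. With bromo on the ring, the sulfanyl link in place of the phenoxy oxygen gives a number 49.1 percentage points higher from compound 2 to compound 4 (beyond the scatter). The step of a number 21.8 percentage points higher from compound 1 to compound 4 (beyond the scatter) alters both places at once, so it cannot separate them.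

As far as these compounds go, whether a methyl or methoxy group at this ring carbon would follow the phenoxy pair or the sulfanyl pair remains open. So does how an amide link would compare with these two links.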